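This account rests on a few compounds, and the source may have more. Where it says the series, first, only, none or still open, it means among the compounds named here.

Working notes on the pyrazole urea and amide series, read in a functional assay on SF-295 cells (Homo sapiens) for inhibition, read by sulforhodamine B assay, with a stated time of 48 h; on this read-out lower numbers stand for stronger inhibition of growth and higher numbers for weaker inhibition of growth.

Compound 3 `COc1cc(-c2nn(-c3cccc(NC(=O)Nc4ccc(Cl)c(Cl)c4)c3)cc2-c2ccncc2)ccc1Cl` gives 2530 nM. For the measured compounds named here, it holds the lowest of the three numbers measured so far, but its neighbours lie close: compound 2 `COc1cc(-c2nn(-c3cccc(NC(=O)c4cccc(C(F)(F)F)c4)c3)cc2-c2ccncc2)ccc1Cl` gives 3000 nM, and compound 1 `O=C(Nc1cccc(-n2cc(-c3ccncc3)c(-c3ccc(Cl)c(O)c3)n2)c1)Nc1cccc(C(F)(F)F)c1` gives 4260 nM, both within the scatter of compound 3. Going by the values given here, the one step available, a 1.2-fold lower number from compound 2 to compound 3 (0.07 log units; within the scatter), did not move the number beyond the scatter.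

Compound 4 `COc1cc(-c2nn(-c3cccc(NC(=O)Nc4cccc(C(F)(F)F)c4)c3)cc2-c2ccncc2)ccc1Cl` is not yet measured. The change from compound 3 is 3-(trifluoromethyl)phenyl in place of 3,4-dichlorophenyl on an amide-type nitrogen. Among the compounds with values here, no measured step covers exactly this swap; the step from compound 2 to compound 3 is the nearest, and it was flat. Compound 1 carries the same trifluoromethylphenyl urea on a core that differs only in its hydroxy rather than methoxy group and gives a number within the scatter of compound 3. The expectation for this assay is therefore no step beyond the scatter, a 1.2-fold higher number from compound 3 to compound 4 (0.07 log units; within the scatter). Compound 4 is estimated at 3000 nM, with a range of 1500 nM to 6000 nM.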

Compound 4, concentration for total growth inhibition: 1130 nM
Estimate against measurement, compound 4: 2.7-fold (0.42 log units) above; the whole stated range lies above it.
By their numbers in this assay, from the lowest: compound 4; then compounds 3, 2 and 1 (each within the scatter of the next).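

In this assay, for the compounds shown here, the aryl group on the urea nitrogen is the first change to move the number beyond the scatter: a 2.2-fold lower number from compound 3 to compound 4 (0.35 log units; beyond the scatter), with 3-(trifluoromethyl)phenyl in place of 3,4-dichlorophenyl. The other two single changes reaching compound 4 are also modest but beyond the scatter: a 2.7-fold lower number from compound 2 to compound 4 (0.42 log units; beyond the scatter) with the urea nitrogen present, and a 3.8-fold lower number from compound 1 to compound 4 (0.58 log units; beyond the scatter) with methyl in place of hydrogen on the oxygen. The flat step, a 1.2-fold lower number from compound 2 to compound 3 (0.07 log units; within the scatter), therefore changed the linker and the aryl group together, and the two single changes now read in opposite directions.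

Nothing at hand accounts for any of these steps. Still open, from the compounds shown here alone, is how a nitrile or a single chlorine in place of trifluoromethyl, or an ethyl in place of the methyl on the oxygen, would read in this assay.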